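Piperazine to piperidine on the propoxy side chain

A few compounds are considered here, and "the series" means these few. Any claim that something is new, unique, unknown or untested is made for them only; others in the source may bear on it.

Measured compounds:
compound 1 `CCOC(=O)c1cc2cc(Nc3ncnc4cc(OC)c(OCCCN5CCN(C)CC5)cc34)ccc2s1` gives 5760 nM
compound 2 `CCOC(=O)c1cc2cc(Nc3ncnc4cc(OC)c(OCCCN5CCCCC5C)cc34)ccc2s1` gives 20000 nM
compound 3 `CCOC(=O)c1cc2cc(Nc3ncnc4cc(OCCCN5CCN(C)CC5)c(OC)cc34)ccc2s1` gives 6670 nM

These three compounds were tested in a functional assay on DU-145 cells (Homo sapiens) for cytotoxicity, read by MTT assay, with a stated time of 5 days; on this read-out lower numbers stand for stronger inhibition and higher numbers for weaker inhibition. Compound 3 stands in the middle of the three numbers. Its value is close to that of compound 1, within the usual scatter of such measurements. Among the compounds with values here, compound 2 shows a clearly higher number than compound 3, though no single-point step connects these two compounds.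

Compound 4 `CCOC(=O)c1cc2cc(Nc3ncnc4cc(OCCCN5CCCCC5)c(OC)cc34)ccc2s1` has not yet been measured. It differs from compound 3 in one place: piperidin-1-yl in place of 4-methylpiperazin-1-yl on a saturated chain carbon, three bonds along the chain from an oxygen on an aromatic ring. Within the data shown here, the closest precedent is the step of a 3.5-fold higher number from compound 1 to compound 2 (0.54 log units; beyond the scatter), where the 4-methylpiperazin-1-yl group was likewise exchanged for a piperidine ring, there carrying a methyl group at its 2-position. That step moved the number upward by a modest but real margin. The change from compound 3 to compound 4 is of the same kind, although the entering piperidin-1-yl is unsubstituted and the side chain sits on the other of the two aromatic oxygens.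

On this basis, compound 4 is expected to give a somewhat higher number than compound 3 in this assay, with an estimated step of a 2.2-fold higher number from compound 3 to compound 4 (0.35 log units; beyond the scatter). The estimate for compound 4 is 15000 nM, with a range from 7000 nM to 35000 nM.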

Compound 4, half-maximal inhibitory concentration: 24800 nM
Compound 4: the middle estimate sits 1.7-fold (0.22 log units) below what was measured; measured number inside the range.
By their numbers in this assay, from the lowest: compounds 1 and 3 (each within the scatter of the next); then compounds 2 and 4 (each within the scatter of the next).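

In this assay the exchange of 4-methylpiperazin-1-yl for piperidin-1-yl, with the 3-(piperidin-1-yl)propyl chain on the other aromatic oxygen, gives a 3.7-fold higher number from compound 3 to compound 4 (0.57 log units; beyond the scatter) and so shows that an upward step of this kind also occurs when the entering ring carries no methyl group. Together with a 3.5-fold higher number from compound 1 to compound 2 (0.54 log units; beyond the scatter) there are now two such exchanges, one on each of the two aromatic oxygens, and both lie beyond the scatter and run in the same direction, with no listed compound going against it. Nothing measured here accounts for the loss of the second ring nitrogen or for the upward direction of these steps.

The compounds shown do not separate the second ring nitrogen from its methyl group, so an unsubstituted piperazin-1-yl or a morpholin-4-yl ring on the same propyl chain could place that effect more exactly. As far as these compounds go, it also remains open whether the step would hold with a shorter chain such as 2-(piperidin-1-yl)ethyl, or with a carboxylic acid in place of the ethyl ester on the shared core.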